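The source may report more compounds than this note shows. Statements on the series, on what has been measured and on what is new or still open speak of the compounds shown alone.

The study is concerned with two benzoxazole-bearing sulfonamides in an ADME assay on HEK293 cells (Homo sapiens) for cytotoxicity, read by resazurin assay, with a stated time of 48 h; on this read-out higher numbers stand for lower toxicity in this test and lower numbers for higher toxicity in this test. Compound 1 `O=S(=O)(Nc1ccc(-c2nc3ccccc3o2)cc1)c1ccc(C(F)(F)F)cc1` gives 94000 nM in this assay. Compound 2 `O=S(=O)(Nc1ccc2oc(-c3ccccc3)nc2c1)c1ccccc1F` gives 72000 nM in this assay. These two numbers sit close to each other, their gap lying within the scatter of repeated measurements, so compound 1 cannot be set apart from compound 2 on this read-out.

The step under study leads from compound 1 to compound 3 `Cc1ccc(S(=O)(=O)Nc2ccc(-c3nc4ccccc4o3)cc2)cc1`, which has not yet been measured in this assay. The change is methyl in place of trifluoromethyl on an aromatic carbon. Among the compounds with values here, no measured pair in the set shares this change, so nothing in the data speaks to its effect. Given that both measured compounds fall in the same region, the step is expected to be small, estimated as a 1.1-fold higher number from compound 1 to compound 3 (0.03 log units; within the scatter), with no clear direction beyond the scatter. Compound 3 is accordingly expected to give about 100000 nM in this assay, within a range of 45000 nM to 220000 nM.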

Compound 3, half-maximal cytotoxic concentration: 88000 nM
Compound 3: the middle estimate sits 1.1-fold (0.06 log units) above what was measured, and the stated range covers the measured number.
By their numbers in this assay, from the lowest: compounds 2, 3 and 1 (each within the scatter of the next).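

In this assay, within the data shown here, methyl in place of trifluoromethyl on this aromatic carbon, para to a large group, gives a 1.1-fold lower number from compound 1 to compound 3 (0.03 log units; within the scatter), so at this position the change leaves no step that can be told apart from the scatter. Among these compounds, this is the first reading for the position, and it shows that the exchange of a group of 4 heavy atoms for one of 1 heavy atom leaves the read-out in the same region. Nothing available explains why the number holds across this change.

The compounds shown leave open whether another group at this carbon, such as an amine, a carboxylic acid or a longer chain, would also stay within the scatter of compound 1. They also leave open whether the same change would give a similar step on a different core.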